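Benzyl swap across two cores: inhibition of the enzyme

The compounds below may be only part of what the source reports. "The series", "measured", "known", "first", "only" and "open" are said of these compounds alone.

Measured so far:
compound 1, `Cc1ccc(COc2ccc(-c3nn(CCC#N)c(=O)o3)cc2)cc1`, 15 nM
compound 2, `N#CCCn1nc(-c2ccc(OCc3cccc(Cl)c3)cc2)oc1=O`, 12 nM
compound 3, `Cc1ccc(COc2ccc(-c3nn(CCC#N)c(=S)o3)cc2)cc1`, 400 nM

The values come from an assay for inhibition of Amine oxidase [flavin-containing] B (Rattus norvegicus); a lower number here means a stronger inhibitor, a higher number a weaker inhibitor. Compound 1 and compound 2 differ by 3-chlorophenyl in place of 4-methylphenyl on a saturated chain carbon bound to an oxygen on an aromatic ring; the step is a 1.3-fold lower number from compound 1 to compound 2 (0.10 log units; within the scatter), so the two values lie within the scatter of each other. Compound 3 shares the benzyl ether and nitrile chain with compound 1 but has a different core; that difference between the two cores is not broken down here. What the values show is that compound 3 gives the highest number of the three, beyond the scatter from both compound 1 and compound 2.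

Compound 4, `N#CCCn1nc(-c2ccc(OCc3cccc(Cl)c3)cc2)oc1=S`, is not yet measured. It differs from compound 3 by 3-chlorophenyl in place of 4-methylphenyl on a saturated chain carbon bound to an oxygen on an aromatic ring, at the same place as the change from compound 1 to compound 2, so this is the same change made on the core of compound 3. Compound 4 is expected to move by about a 1.3-fold lower number from compound 3 to compound 4 (0.10 log units; within the scatter) because the earlier step of a 1.3-fold lower number from compound 1 to compound 2 (0.10 log units; within the scatter) stayed within the scatter. Compound 4 is therefore estimated at 320 nM, with a range from 150 nM to 700 nM.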

Compound 4, half-maximal inhibitory concentration: 160 nM
Compound 4: the middle estimate sits 2.0-fold (0.30 log units) above what was measured; the measured number falls inside the stated range.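

In this assay, the change from 4-methylbenzyl to 3-chlorobenzyl gives a 2.5-fold lower number from compound 3 to compound 4 (0.40 log units; beyond the scatter), set against a 1.3-fold lower number from compound 1 to compound 2 (0.10 log units; within the scatter) on the other core. As far as these two pairs can tell, the change carries from one core to the other without a step size that can be separated by core: the same change on two cores in this assay, a 1.3-fold lower number (0.10 log units; within the scatter) from compound 1 to compound 2 and a 2.5-fold lower number (0.40 log units; beyond the scatter) from compound 3 to compound 4, 2.0-fold (0.30 log units) apart, within the scatter of two such steps. This rests on a single pair per core and a single change, so it does not show that the step would hold on any further core, nor that the larger of the two steps belongs to its core.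

The compounds shown leave open whether other groups in place of the 3-chlorobenzyl, such as a 4-fluorobenzyl or a 3-methoxybenzyl, would carry between the two cores in the same way. Also open, on these data alone, is how an amine or a carboxylic acid in place of the nitrile, or a longer chain bearing the nitrile, would behave on either core.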